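The compounds below may be only part of what the source reports. "The series", "measured", "known", "first", "only" and "open" are said of these compounds alone.

Three compounds share one core and were tested in a functional assay on A375P cells (Homo sapiens) for antiproliferative activity, read by MTT assay, with a stated time of 48 h; a higher number here means a weaker inhibitor, a lower number a stronger inhibitor. Compound 1 `Nc1cccc2c(-c3cccc(NC(=O)c4ccc(Cl)c(C(F)(F)F)c4)c3)ccnc12` gives 1400 nM. Compound 2 `CC(=O)Nc1cccc2c(-c3cccc(NC(=O)c4ccc(Cl)c(C(F)(F)F)c4)c3)ccnc12` carries an acetyl on the amino nitrogen instead of a hydrogen, and compound 2 gives 2400 nM; the step is a 1.7-fold higher number from compound 1 to compound 2 (0.23 log units; within the scatter). Compound 3 `Cc1ccc(NC(=O)c2ccc(Cl)c(C(F)(F)F)c2)cc1-c1ccnc2c(N)cccc12` instead carries a methyl on an aromatic carbon, and compound 3 gives 3300 nM, the highest of the three numbers, with the step of a 2.4-fold higher number from compound 1 to compound 3 (0.37 log units; beyond the scatter); the numbers for compound 3 and compound 2 lie within the scatter of each other.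

Compound 4 `CC(=O)Nc1cccc2c(-c3cc(NC(=O)c4ccc(Cl)c(C(F)(F)F)c4)ccc3C)ccnc12` has not yet been measured. It differs from compound 3 by acetyl in place of hydrogen on a nitrogen on an aromatic ring, which, cut one bond further out, reads amino to acetamido. Among the compounds with values here, the one measured step that bears on this change is the same change made on compound 1, a 1.7-fold higher number from compound 1 to compound 2 (0.23 log units; within the scatter), which stayed within the scatter. On that basis the step is expected to be small, toward a higher number or none beyond the scatter, a 1.5-fold higher number from compound 3 to compound 4 (0.18 log units; within the scatter). Compound 4 is therefore estimated to give 5000 nM, somewhere between 2500 nM and 10000 nM.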

Compound 4, half-maximal inhibitory concentration: 12200 nM
Beside the measured number, compound 4's estimate is 2.4-fold (0.39 log units) below it, outside the stated range (above it).
By their numbers in this assay, from the lowest: compounds 1, 2 and 3 (each within the scatter of the next, the first and the last beyond it); then compound 4.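

In this assay, acetyl in place of hydrogen on the nitrogen now gives a step beyond the scatter, a 3.7-fold higher number from compound 3 to compound 4 (0.57 log units; beyond the scatter), and methyl on the aromatic carbon, with the acetamido already present, gives a 5.1-fold higher number from compound 2 to compound 4 (0.71 log units; beyond the scatter). Even so, the acetyl step cannot be said to grow on the methyl-bearing core: the same change on two cores in this assay, a 1.7-fold higher number (0.23 log units; within the scatter) from compound 1 to compound 2 and a 3.7-fold higher number (0.57 log units; beyond the scatter) from compound 3 to compound 4, 2.2-fold (0.33 log units) apart, within the scatter of two such steps. Nor can the methyl step be said to grow with the acetamido present: the same change on two cores in this assay, a 2.4-fold higher number (0.37 log units; beyond the scatter) from compound 1 to compound 3 and a 5.1-fold higher number (0.71 log units; beyond the scatter) from compound 2 to compound 4, 2.2-fold (0.33 log units) apart, within the scatter of two such steps.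

From the compounds shown here alone, with only these pairs, it remains open whether the two changes simply add up or reinforce each other. Going by these compounds, it is also open whether another group on that nitrogen, such as propionyl or methanesulfonyl, or another group on that aromatic carbon, such as ethyl or chlorine, would follow the same course.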